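The compounds below may be only part of what the source reports. "The series", "measured", "known", "first", "only" and "open" are said of these compounds alone.

Three hydrazone-type compounds sharing the same core have been tested in a functional assay on CCRF-CEM cells (Homo sapiens) for antiproliferative activity, read by MTT assay; on this read-out lower numbers stand for stronger inhibition and higher numbers for weaker inhibition. Compound 1 `c1ccc(C(=NNc2nc3ccccc3o2)c2ccccn2)nc1` gives 44 nM. Compound 2 `CC(C)/C(=N\Nc1nc2ccccc2o1)c1ccccn1` gives 21 nM, the lowest of the three numbers, with compound 1 as its nearest neighbour at a gap beyond the usual scatter. Compound 3 `C/C(=N\Nc1nc2ccccc2o1)c1nccnc1C` gives 1300 nM, by far the weakest of the set and the furthest from compound 2.

The next compound, compound 4 `C/C(=N\Nc1nc2ccccc2o1)c1ccccn1`, is a close relative of compound 2. The change is small: methyl in place of isopropyl on a carbon with a double bond to nitrogen. The aromatic ring attached to that carbon stays the same, so compound 4 tests only what the size of the alkyl group contributes. Compound 3 also carries a methyl at this position, but its aromatic ring is different, so its weak result cannot be read as the effect of the methyl alone.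

Within the data shown here, with no directly comparable pair among the measured compounds, the step from isopropyl to methyl is expected to be modest, most likely a small move towards weaker inhibition or none beyond the scatter. For compound 4 the expected result in this assay is 40 nM, within a range of 10 nM to 160 nM, which means an expected step of a 1.9-fold higher number from compound 2 to compound 4 (0.28 log units; within the scatter).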

Compound 4, half-maximal inhibitory concentration: 15 nM
The estimate for compound 4 lay 2.7-fold (0.43 log units) above the measured number, and the stated range covers the measured number.
By their numbers in this assay, from the lowest: compounds 4 and 2 (each within the scatter of the next); then compound 1; then compound 3.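

In this assay, putting methyl in place of isopropyl on the carbon with a double bond to nitrogen gives a 1.4-fold lower number from compound 2 to compound 4 (0.15 log units; within the scatter) and stays within the scatter, so compound 2 and compound 4 cannot be told apart, and this position gives the same reading with either 1 or 3 heavy atoms in the alkyl group. It also shows that a methyl here does not by itself go with a weak number: compound 4 carries this methyl and gives 15 nM in this assay, while compound 3, which carries a methyl here on a different aromatic ring, gives 1300 nM as its printed value. Nothing at hand explains why the two alkyl groups give such similar numbers.

The compounds shown cover only two small alkyl groups and one aromatic replacement at this carbon, so it remains open whether a longer chain, such as an n-hexyl group, would keep the number in this range. Going by these compounds, it is equally open whether an amine or a carboxylic acid on that chain would do the same.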